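The compounds below may be only part of what the source reports. "The series", "measured", "known", "first", "only" and "open" are said of these compounds alone.

Measured compounds in an ADME assay on Huh-7 cells (Homo sapiens) for cytotoxicity; on this read-out higher numbers stand for lower toxicity in this test and lower numbers for higher toxicity in this test:
compound 1, `O=C(NC(=S)N1CCc2c(OCCCCCOc3ccc(Cl)cc3)cccc21)c1ccc(F)cc1`: 31100 nM
compound 2, `Cc1ccc(C(=O)NC(=S)N2CCc3c(OCCCCCOc4ccc(Cl)cc4)cccc32)cc1`: limit of the assay, > 50000 nM

Compound 2 gives only a limit in this assay, no number. For the measured compounds named here, the one measured step, an at least 1.6-fold higher number from compound 1 to compound 2 (0.20 log units; that floor lies within the scatter), is a methyl in place of a fluoro and is bounded by the limit of > 50000 nM in this assay, at which 1 of the 2 values shown sits. Compound 3, `CC(C)(C)c1ccc(C(=O)NC(=S)N2CCc3c(OCCCCCOc4ccc(Cl)cc4)cccc32)cc1`, differs from compound 2 by tert-butyl in place of methyl on an aromatic carbon. Going by the values given here, no measured step bears on a methyl to tert-butyl exchange; the only step known sits at the scatter floor. Compound 3 is therefore expected to show an at least 1.1-fold lower number from compound 2 to compound 3 (0.04 log units; that floor lies within the scatter), none beyond the scatter. Compound 3 is estimated at 45000 nM, within 15000 nM to 100000 nM.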

Compound 3, half-maximal cytotoxic concentration: > 50000 nM
Compound 3 gave a limit, no number; the forecaster's own chance of this, stated with the estimate: 40%; middle value at least 1.1-fold (0.04 log units) away from the limit.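

In this assay compound 3 gives > 50000 nM as a limit of the assay and not a number, so tert-butyl on this aromatic carbon, with 4 heavy atoms against 1 for methyl, also yields no readable value. Tert-butyl in place of fluoro gives an at least 1.6-fold higher number from compound 1 to compound 3 (0.20 log units; that floor lies within the scatter) and so shows no step beyond the scatter. The step from methyl to tert-butyl cannot be read, because both values are limits: the limit of > 50000 nM in this assay, at which 2 of the 3 values shown sit.

From the compounds shown here alone, whether an amine or a carboxylic acid on this aromatic carbon would give a readable value in this assay remains open.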